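The compounds below may be only part of what the source reports. "The series", "measured", "known", "first", "only" and "open" are said of these compounds alone.

Compound 1, `CCCCSc1nc(N)nc2c1ncn2/C=C1/CC1(CO)CO`, gives > 20000 nM in an ADME assay on Akata cells (Homo sapiens) for cytotoxicity, with a stated time of 7 days (a lower number here means that less compound is tolerated, a higher number that more compound is tolerated), which is a limit rather than a number.
Compound 2, `CCCNc1nc(N)nc2c1ncn2/C=C1/CC1(CO)CO`, gives > 24000 nM in this assay, again a limit.
Compound 3, `Nc1nc(OCC(F)(F)F)c2ncn(/C=C3/CC3(CO)CO)c2n1`, gives > 20000 nM in this assay, also a limit.

Compound 3 therefore stands at a limit, and the two other values shown are limits as well: the limit of > 20000 nM in this assay, at which 2 of the 3 values shown sit, and (the limit of > 24000 nM in this assay, at which 1 of the 3 values shown sits). The three steps among the measured compounds, a step that the two limits leave unreadable from compound 1 to compound 2, a step that the two limits leave unreadable from compound 1 to compound 3 and a step that the two limits leave unreadable from compound 2 to compound 3, are all left unreadable by those limits, so no direction or size can be drawn from them.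

The step to compound 4, `Nc1nc(NC2CCCC2)c2ncn(/C=C3/CC3(CO)CO)c2n1`, is cyclopentylamino in place of 2,2,2-trifluoroethoxy on an aromatic carbon. The measured step that comes closest to it is a step that the two limits leave unreadable from compound 2 to compound 3, an exchange of an amino group and an ether on the same aromatic carbon, but its size is not readable. With every value shown sitting at a limit, no step beyond the scatter is expected in this assay from compound 3 to compound 4, and compound 4 is expected to sit at a limit too. Compound 4 is estimated at 30000 nM, in the range 15000 nM to 100000 nM, meaning an expected step that the limit leaves unreadable from compound 3 to compound 4.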

Compound 4, half-maximal cytotoxic concentration: > 20000 nM
Compound 4 gave a limit, no number (the forecaster's own chance of this, stated with the estimate: 75%); the middle value lies beyond the limit too.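

Compound 4 gives > 20000 nM in this assay, which is a limit. Within the data shown here, its steps to compound 1, compound 2 and compound 3 cannot be read, so this result yields no new step. The compounds shown leave open at what concentration any of them becomes cytotoxic, and whether exchanging the groups on the aromatic carbon changes that concentration.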